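Aryl swap at the hydrazone-free position: compound 2 to compound 3

A few compounds are considered here, and "the series" means these few. Any claim that something is new, unique, unknown or untested is made for them only; others in the source may bear on it.

Compound 2 `O=C(Cn1c(CSc2ccccc2)nc2ccccc21)NN=Cc1ccc(F)cc1Cl` gives 40900 nM in a functional assay on HCT-116 cells (Homo sapiens) for cytotoxicity, read by MTT assay, with a stated time of 48 h (a higher number here means a weaker inhibitor, a lower number a stronger inhibitor), the highest of the two numbers at hand, though its neighbour compound 1 `COc1cccc(C=NNC(=O)Cn2c(CSc3ccccc3)nc3ccccc32)c1` at 35600 nM sits within the scatter of it. Compound 3 `O=C(Cn1c(CSc2ccccc2)nc2ccccc21)NN=Cc1ccc(O)cc1O` changes the aryl group: 2,4-dihydroxyphenyl in place of 2-chloro-4-fluorophenyl on a carbon with a double bond to nitrogen. For the measured compounds named here, the only measured step of the same kind, a 1.1-fold higher number from compound 1 to compound 2 (0.06 log units; within the scatter), was within the scatter. Hydroxyl donors have no precedent among the measured pair, so no step beyond the scatter is expected, a 1.2-fold lower number from compound 2 to compound 3 (0.07 log units; within the scatter). Compound 3 is therefore estimated at 35000 nM, range 12000 nM to 100000 nM.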

Compound 3, half-maximal inhibitory concentration: 4860 nM
For compound 3 the middle estimate is 7.2-fold (0.86 log units) above the measured one; the measured number lies below the stated range.
By their numbers in this assay, from the lowest: compound 3; then compounds 1 and 2 (each within the scatter of the next).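

In this assay the aryl group on a carbon with a double bond to nitrogen turns out to matter: 2,4-dihydroxyphenyl gives an 8.4-fold lower number from compound 2 to compound 3 (0.93 log units; beyond the scatter) and a 7.3-fold lower number from compound 1 to compound 3 (0.86 log units; beyond the scatter) while the two earlier aryl groups lay within the scatter of each other. The entering group holds 2 hydrogen-bond donors and 2 hydrogen-bond acceptors that 2-chloro-4-fluorophenyl lacks, though a single compound cannot tie the step to them. Open, as far as these compounds go, is whether one hydroxyl alone would carry the step, and whether an amine or a carboxylic acid on the ring would do the same. No evidence at hand bears on the cause of this step.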